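The source may hold more compounds than are shown below. What is called first, only, known or untested is meant among the compounds shown, and "the series" means these compounds.

Measured so far in an assay on CHO cells for antagonist activity at transient receptor potential cation channel subfamily V member 1 (Homo sapiens), read by FLIPR; on this read-out lower numbers stand for stronger inhibition and higher numbers for weaker inhibition:
compound 1 `CC1CCN(c2cc(C(F)(F)F)ccc2CNC(=O)C(C)c2ccc(NS(C)(=O)=O)c(F)c2)CC1` gives 0.9 nM;
compound 2 `CC(C(=O)NCc1ccc(C(F)(F)F)cc1N1CCC(Cc2ccccc2)CC1)c1ccc(NS(C)(=O)=O)c(F)c1` gives 1.4 nM;
compound 3 `CC(C(=O)NCc1ccc(C(F)(F)F)cc1N1CCC(Cc2ccc(F)cc2)CC1)c1ccc(NS(C)(=O)=O)c(F)c1` gives 0.4 nM.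

Compound 1 stands second highest of the three numbers: the step of a 1.6-fold higher number from compound 1 to compound 2 (0.19 log units; within the scatter) lies within the scatter, while a 2.3-fold lower number from compound 1 to compound 3 (0.35 log units; beyond the scatter) lies beyond it. Compound 4 `CC(C(=O)NCc1ccc(C(F)(F)F)cc1OC1CCCC1)c1ccc(NS(C)(=O)=O)c(F)c1` differs from compound 1 by cyclopentyloxy in place of 4-methylpiperidin-1-yl on an aromatic carbon. Within the data shown here, none of the measured steps bears directly on this change: each of them alters only the group on the saturated chain carbon bound to a saturated ring carbon, and all stayed modest, as a 3.5-fold lower number from compound 2 to compound 3 (0.54 log units; beyond the scatter) shows. Here the whole six-membered non-aromatic ring with one hetero atom leaves and a cyclopentyloxy group enters in its place, a larger change than any measured. Compound 4 is therefore expected to give a somewhat higher number, a step of a 3.3-fold higher number from compound 1 to compound 4 (0.52 log units; beyond the scatter), with an estimate of 3 nM and a range of 0.8 nM to 12 nM.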

Compound 4, inhibition constant: 0.6 nM
Beside the measured number, compound 4's estimate is 5.0-fold (0.70 log units) above it; measured number outside the range, below it.
By their numbers in this assay, from the lowest: compounds 3, 4, 1 and 2 (each within the scatter of the next, the first and the last beyond it).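

In this assay, putting cyclopentyloxy in place of 4-methylpiperidin-1-yl brings a 1.5-fold lower number from compound 1 to compound 4 (0.18 log units; within the scatter) and so no real change. The earlier compounds shown here varied only the far end of the saturated ring, whereas this result shows that the aromatic carbon ortho to a large group can carry a different ring, joined through oxygen instead of nitrogen, with the read-out holding. Nothing available explains why the two groups read alike. The compounds shown leave open how a small group such as methoxy, or an open-chain amine such as dimethylamino, would read on this carbon.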